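A few compounds are considered here, and "the series" means these few. Any claim that something is new, unique, unknown or untested is made for them only; others in the source may bear on it.

Compound 1 `N#CC1CN1C(=O)Nc1ccc(Cl)c(Cl)c1` and compound 2 `N#CC1CN1C(=O)Nc1ccc(F)cc1` share a core and differ only in what sits on the aromatic ring. In a functional assay on WiDr cells (Homo sapiens) for inhibition (a lower number here means a stronger inhibitor, a higher number a weaker inhibitor), compound 1 gives 14000 nM. In this assay compound 2 gives 9000 nM. These two numbers lie within the usual scatter of each other, so neither compound can be called the stronger inhibitor on this evidence; compound 2 simply carries the smaller number of the pair.

Compound 3 `N#CC1CN1C(=O)Nc1ccc([N+](=O)[O-])cc1` is not yet measured. It arises from compound 2 by nitro in place of fluoro on an aromatic carbon, a nitro in place of fluoro on an aromatic carbon. Within the data shown here, no measured pair shows what such an exchange does here, so the expectation rests only on compound 2 and compound 1. The step from compound 2 to compound 3 is expected to be small, a 1.5-fold lower number from compound 2 to compound 3 (0.18 log units; within the scatter), and not clearly beyond the scatter in either direction. For compound 3 the estimate in this assay is 6000 nM, with a range from 2000 nM to 20000 nM.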

Compound 3, half-maximal inhibitory concentration: 3700 nM
For compound 3 the middle estimate is 1.6-fold (0.21 log units) above the measured one, within the range that was stated.
By their numbers in this assay, from the lowest: compound 3; then compounds 2 and 1 (each within the scatter of the next).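

In this assay, among these compounds, nitro in place of fluoro on an aromatic carbon gives a 2.4-fold lower number from compound 2 to compound 3 (0.39 log units; beyond the scatter) and so provides the one single-place exchange in this set whose size clears the usual scatter. The position para to a group of 8 heavy atoms is therefore not indifferent to what it carries, although the step is only modest. The data offer no measured property that would explain this shift.

With only fluoro and nitro compared directly at this position, a single step cannot show a trend. From the compounds shown here alone, an amine, a methoxy group or a carboxylic acid in the same place could move the number in either direction, and the effect of changing the nitrile on the shared core also remains open.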